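The source may hold more compounds than are shown below. What is called first, only, known or untested is meant among the compounds shown, and "the series" means these compounds.

Series notes. In a functional assay on B16-F10 cells (Mus musculus) for antiproliferative activity, read by MTT assay, with a stated time of 48 h (on this read-out lower numbers stand for stronger inhibition and higher numbers for weaker inhibition), compound 1 `Cc1ccc(-c2nn(-c3ccccc3)cc2CNc2ccc(Br)cc2)cc1` gives 6760 nM, compound 2 `Clc1ccc(-c2nn(-c3ccccc3)cc2CNc2ccc(Br)cc2)cc1` gives 3010 nM and compound 3 `Clc1ccc(NCc2cn(-c3ccccc3)nc2-c2ccc(Cl)cc2)cc1` gives 2450 nM. Compound 4 `Cc1ccc(-c2nn(-c3ccccc3)cc2CNc2ccc(Cl)cc2)cc1` has not yet been measured there. The cores of compound 2 and compound 3 differ by chloro in place of bromo on an aromatic carbon, which makes a step of a 1.2-fold lower number from compound 2 to compound 3 (0.09 log units; within the scatter). From compound 2 to compound 1 the change is methyl in place of chloro on an aromatic carbon, with a step of a 2.2-fold higher number from compound 2 to compound 1 (0.35 log units; beyond the scatter). The same change, (methyl in place of chloro on an aromatic carbon), applied to the core of compound 3 gives compound 4, and its place reads word for word as in the earlier pair. A step of the same size is expected because of a 2.2-fold higher number from compound 2 to compound 1 (0.35 log units; beyond the scatter), taken from compound 3 at 2450 nM. Compound 4 is therefore expected to move by a 2.2-fold higher number from compound 3 to compound 4 (0.34 log units; beyond the scatter). For compound 4 the estimate is 5400 nM, expected to fall between 2700 nM and 11000 nM.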

Compound 4, half-maximal inhibitory concentration: 6010 nM
For compound 4 the middle estimate is 1.1-fold (0.05 log units) below the measured one; the measured number falls inside the stated range.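

In this assay, methyl in place of chloro gives a 2.5-fold higher number from compound 3 to compound 4 (0.39 log units; beyond the scatter), which matches the step seen on the other core: the same change on two cores in this assay, a 2.2-fold higher number (0.35 log units; beyond the scatter) from compound 2 to compound 1 and a 2.5-fold higher number (0.39 log units; beyond the scatter) from compound 3 to compound 4, 1.1-fold (0.04 log units) apart, within the scatter of two such steps. Chloro in place of bromo gives a 1.1-fold lower number from compound 1 to compound 4 (0.05 log units; within the scatter), and this small step also holds on both cores: the same change on two cores in this assay, a 1.2-fold lower number (0.09 log units; within the scatter) from compound 2 to compound 3 and a 1.1-fold lower number (0.05 log units; within the scatter) from compound 1 to compound 4, 1.1-fold (0.04 log units) apart, within the scatter of two such steps. These two pairs show that each change carries over between these two cores in this one assay, but they do not show that it would do so on any other core, nor why the steps agree.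

The compounds shown leave open whether an amine, a carboxylic acid or a longer chain at the place of the methyl would continue the same trend. They also leave open how a group other than chloro or bromo would behave on the other aromatic ring.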